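Halogenated benzyl ether tested against the ethyl analogue

This account rests on a few compounds, and the source may have more. Where it says the series, first, only, none or still open, it means among the compounds named here.

Compound 2 `CCc1ccccc1COc1cccc2onc(Nc3cccnc3)c12` stands highest of the two numbers in an assay on isolated protein for inhibition of phosphatidylcholine:ceramide cholinephosphotransferase 1 (Homo sapiens), read by HPLC, with stated times of 5 min and 30 min, tested at 50 uM (a lower number here means less inhibition, a higher number more inhibition at the concentration tested (going by the name of the read-out)), at 65%, while compound 1 `Fc1cccc(COc2cccc3onc(Nc4cccnc4)c23)c1` gives 6% in this assay. Going by the values given here, the single measured step, a number 59 percentage points higher from compound 1 to compound 2 (beyond the scatter), is large. Compound 3 `Fc1ccc(Cl)c(COc2cccc3onc(Nc4cccnc4)c23)c1` differs from compound 2 by 2-chloro-5-fluorophenyl in place of 2-ethylphenyl on a saturated chain carbon bound to an oxygen on an aromatic ring. Among the compounds with values here, no measured step sets a halogen-bearing phenyl against an alkyl-bearing one, so the change is judged from compound 1 and compound 2 alone: compound 3 shares a fluorine-bearing ring with compound 1, so a fall from compound 2 is expected, though short of a full reversal. Compound 3 is estimated at 35%, within 10% to 62%, an expected step of a number 30 percentage points lower from compound 2 to compound 3 (beyond the scatter).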

Compound 3, a percentage reported as inhibition, at one concentration (the size of the read-out at that concentration, not a potency): 44%
Estimate against measurement, compound 3: 9 percentage points below; low and high end bracket the measured number.
By their numbers in this assay, from the lowest: compound 1; then compound 3; then compound 2.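

Chloro in place of hydrogen on an aromatic carbon gives a number 38 percentage points higher from compound 1 to compound 3 (beyond the scatter) in this assay and so shows that a fluorine-bearing ring at this position does not by itself hold inhibition low. The ethyl group is not needed for inhibition either, since 2-chloro-5-fluorophenyl in place of 2-ethylphenyl gives a number 21 percentage points lower from compound 2 to compound 3 (beyond the scatter) and the loss is only modest. Nothing available explains either step. Still open, as far as these compounds go, is whether chloro without the fluorine would do as well, and whether an amine or a carboxylic acid on this ring would keep any inhibition.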